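A few compounds are considered here, and "the series" means these few. Any claim that something is new, unique, unknown or untested is made for them only; others in the source may bear on it.

Of the compounds shown here, three built on one shared core have been tested in an assay on isolated protein for inhibition of myosin-2 (Bos taurus), read by spectrophotometry, with a stated time of 24 min; on this read-out higher numbers stand for weaker inhibition and lower numbers for stronger inhibition. Compound 1 `C/C(=N\Cc1cccc(C)c1)c1c(O)c2ccccc2oc1=O` gives 4900 nM. Compound 2 `C/C(=N\Cc1ccccn1)c1c(O)c2ccccc2oc1=O` gives 22000 nM, and compound 3 `C/C(=N\CCCO)c1c(O)c2ccccc2oc1=O` gives 37000 nM. Going by the values given here, compound 3 carries the highest number of the three, but only the step of a 7.6-fold higher number from compound 1 to compound 3 (0.88 log units; beyond the scatter) is beyond the scatter; the step of a 1.7-fold higher number from compound 2 to compound 3 (0.23 log units; within the scatter) is within it, so compound 3 and compound 2 cannot be told apart on these numbers. The step of a 4.5-fold higher number from compound 1 to compound 2 (0.65 log units; beyond the scatter) is also beyond the scatter.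

Compound 4 `C/C(=N\Cc1ccccc1C)c1c(O)c2ccccc2oc1=O` has not yet been measured. It differs from compound 3 in one place: 2-methylphenyl in place of 2-hydroxyethyl on a saturated chain carbon bound to a double-bonded nitrogen

The measured step that bears most on this change runs the other way, a 7.6-fold higher number from compound 1 to compound 3 (0.88 log units; beyond the scatter), where 2-hydroxyethyl took the place of 3-methylphenyl. Among the compounds with values here, compound 4 restores a methyl-bearing aromatic ring, although it is 2-methylphenyl rather than 3-methylphenyl, and no measured pair shows what that swap alone does. The step from compound 2 to compound 3 was within the scatter and offers no further guide.

The expectation is therefore a drop of roughly the size of the earlier rise, a 6.2-fold lower number from compound 3 to compound 4 (0.79 log units; beyond the scatter), bringing compound 4 close to compound 1. Compound 4 is estimated at 6000 nM, with a range from 2000 nM to 18000 nM.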

Compound 4, half-maximal inhibitory concentration: >= 100000 nM
Compound 4 gave a limit, no number (the forecaster's own chance of this, stated with the estimate: 0%); middle value at least 16-fold (1.22 log units) away from the limit.
By their numbers in this assay, from the lowest: compound 1; then compounds 2 and 3 (each within the scatter of the next). At a limit, above all of these: compound 4.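

Compound 4 sits at a limit of this assay, not at a number: the limit of >= 100000 nM in this assay, at which 1 of the 4 values shown sits. Going by these compounds alone, the sharpest result is an at least 20-fold higher number from compound 1 to compound 4 (1.30 log units; beyond the scatter), where the only change is 2-methylphenyl in place of 3-methylphenyl, so on these two compounds a methyl-bearing aromatic ring at this place does not by itself secure the lower number. The other two steps, an at least 2.7-fold higher number from compound 3 to compound 4 (0.43 log units; beyond the scatter) and an at least 4.5-fold higher number from compound 2 to compound 4 (0.65 log units; beyond the scatter), show that 2-methylphenyl also reads weaker than both 2-hydroxyethyl and pyridin-2-yl on this saturated chain carbon bound to a double-bonded nitrogen, so the two compounds with a methyl-bearing ring stand at opposite ends of the series, compound 1 with the lowest number and compound 4 at the limit.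

The compounds shown leave open how far compound 4 really lies from the others, and how a plain phenyl with no methyl would read, which is the comparison needed to tell what the methyl contributes in either compound. They also leave open how an amine or a carboxylic acid at the end of a longer chain would behave at this place.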